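Working notes: cytotoxicity from compound 2 to compound 4

The compounds below may be only part of what the source reports. "The series", "measured", "known", "first", "only" and "open" are said of these compounds alone.

The series is followed in an ADME assay on HCT-116 cells (Homo sapiens) for cytotoxicity, read by CellTiter-Glo, with a stated time of 72 h; a higher number here means a weaker inhibitor, a lower number a stronger inhibitor. Compound 1 `Cc1cc(C)c(S(=O)(=O)N2CCC(N3CCC(C)CC3)CC2)c(C)c1` returns only a limit in this assay, > 5000 nM. Compound 3 `CC1CCN(C2CCN(S(=O)(=O)c3ccc(OC(F)(F)F)cc3)CC2)CC1` likewise stops at a limit in this assay, > 5000 nM. Compound 2 `CC1CCN(C2CCN(S(=O)(=O)c3ccc(Cl)nc3)CC2)CC1` also gives a limit in this assay, > 10000 nM. On the numbers shown, compound 2 stands at the limit of > 10000 nM in this assay, at which 1 of the 3 values shown sits, while the other two values sit at the limit of > 5000 nM in this assay, at which 2 of the 3 values shown sit. For the measured compounds named here, none of the three is a number, so no step between measured compounds can be put in figures, and nothing here sets one compound apart from another beyond the scatter.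

Compound 4 `CC1CCN(C2CCN(S(=O)(=O)c3cc(Cl)cc(Cl)c3)CC2)CC1` is not yet measured in this assay. It differs from compound 2 in one place: 3,5-dichlorophenyl in place of 6-chloropyridin-3-yl on a sulfonyl sulfur. Going by the values given here, with no measured step to draw on and all three known values at limits, the expected step in this assay, a step that the limit leaves unreadable from compound 2 to compound 4, is none beyond the scatter. For compound 4 the estimated value in this assay is 12000 nM. The expected range for compound 4 runs from 4000 nM to 40000 nM, and a limit rather than a number is thought the likelier outcome.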

Compound 4, half-maximal inhibitory concentration: > 5000 nM
Compound 4 was reported as a limit (the forecaster's own chance of this, stated with the estimate: 70%); the middle value lies beyond the limit too.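

In this assay compound 4 gives > 5000 nM, a limit and not a number. Compound 2 also gives a limit, > 10000 nM. For the compounds shown here, no step from one to the other can be read. The compounds shown leave open whether 3,5-dichlorophenyl in place of 6-chloropyridin-3-yl on a sulfonyl sulfur changes the half-maximal inhibitory concentration at all.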